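Glucagon receptor antagonists: pyrazole substituent swap

A few compounds are considered here, and "the series" means these few. Any claim that something is new, unique, unknown or untested is made for them only; others in the source may bear on it.

Measured compounds:
compound 1 `CC(C)(C)C(Oc1ccc(-n2cc(C(F)(F)F)cn2)cc1)c1ccc(C(=O)NCCC(=O)O)cc1`: 4300 nM
compound 2 `CCCC(Oc1ccc(-n2cc(Cl)cn2)cc1)c1ccc(C(=O)NCCC(=O)O)cc1`: 6500 nM

In a functional assay on cells for antagonist activity at Glucagon receptor (Homo sapiens), read by cAMP accumulation, in the presence of a further agent that is not named here (on this read-out lower numbers stand for stronger inhibition and higher numbers for weaker inhibition), compound 2 gives 6500 nM, the higher of the two numbers, but its distance from compound 1 lies within the scatter, so the two stand level on this read-out. Among the measured compounds shown here, compound 1 carries a trifluoromethyl group on the same five-membered ring yet differs from compound 2 elsewhere too, so no clean step for that single change is available.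

Compound 3 `CCCC(Oc1ccc(-n2cc(C(F)(F)F)cn2)cc1)c1ccc(C(=O)NCCC(=O)O)cc1` carries the change (trifluoromethyl in place of chloro on an aromatic carbon), that is trifluoromethyl in place of chloro on an aromatic carbon, reading as 4-chloro-1H-pyrazol-1-yl to 4-(trifluoromethyl)-1H-pyrazol-1-yl. With the two values shown level, no step beyond the scatter is expected in this assay. The expected step from compound 2 to compound 3 is a 1.4-fold lower number from compound 2 to compound 3 (0.16 log units; within the scatter). Compound 3 is estimated at 4500 nM, with a range from 2000 nM to 11000 nM.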

Compound 3, antagonist equilibrium constant in the Glucagon receptor assay: 5100 nM
Beside the measured number, compound 3's estimate is 1.1-fold (0.05 log units) below it, and the stated range covers the measured number.
By their numbers in the Glucagon receptor assay, from the lowest: compounds 1, 3 and 2 (each within the scatter of the next).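

In the Glucagon receptor assay trifluoromethyl in place of chloro on this aromatic carbon of the five-membered aromatic ring gives a 1.3-fold lower number from compound 2 to compound 3 (0.11 log units; within the scatter) and propyl in place of tert-butyl gives a 1.2-fold higher number from compound 1 to compound 3 (0.07 log units; within the scatter) so neither single change moves this read-out beyond the scatter. The earlier pair carried both changes at once, whereas compound 3 now lets each be read alone. The pyrazole substituent swap does register on another read-out, a physicochemical assay for solubility, measured as kinetic solubility, at pH 6.5 (on this read-out higher numbers stand for higher solubility and lower numbers for lower solubility), where compound 2 gives 70000 nM and compound 3 gives 400000 nM, so the pair separates clearly: the measured solubility of compound 2, 70000 nM, and of compound 3, 400000 nM, a 5.7-fold higher number (0.76 log units; beyond the scatter).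

Going by these compounds, whether a nitrile or a methyl on this aromatic carbon would keep the reading level in the Glucagon receptor assay stays open. Also open, on these data alone, is whether a longer chain in place of propyl would shift either read-out.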